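Carbocyclic aryl in place of pyrimidinyl on the pyrazole acid

This account rests on a few compounds, and the source may have more. Where it says the series, first, only, none or still open, it means among the compounds named here.

Measured compounds, antiproliferative read-out in a functional assay on BJAB cells (Homo sapiens) for antiproliferative activity, with a stated time of 4 days; a lower number here means that less compound is needed, a higher number that more compound is needed for the effect:
compound 1, `Cc1nn(-c2nc(-c3ccc(Cl)c(Cl)c3)c(SC(C)C)s2)c(C(=O)O)c1-c1cncnc1`: 22000 nM
compound 2, `Cc1nn(-c2nc(-c3ccc(Cl)c(Cl)c3)c(SC(C)C)s2)c(C(=O)O)c1-c1cccc(Cl)c1C`: 5100 nM
compound 3, `COc1ccccc1-c1c(C)nn(-c2nc(-c3ccc(Cl)c(Cl)c3)c(SC(C)C)s2)c1C(=O)O`: 14700 nM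

Compound 1 gives the highest number of the three. Toward compound 3 the step is a 1.5-fold lower number from compound 1 to compound 3 (0.18 log units; within the scatter), so the two are not separated; toward compound 2 it is a 4.3-fold lower number from compound 1 to compound 2 (0.63 log units; beyond the scatter). Compound 4 `Cc1cccc(-c2c(C)nn(-c3nc(-c4ccc(Cl)c(Cl)c4)c(SC(C)C)s3)c2C(=O)O)c1` is not yet measured. Its change from compound 1: 3-methylphenyl in place of pyrimidin-5-yl on an aromatic carbon. Both measured steps from compound 1 concern the same kind of swap, a carbocyclic ring for the pyrimidin-5-yl, and both ran downward, one beyond the scatter, one within it. Compound 4 carries a 3-methylphenyl and not the 3-chloro-2-methylphenyl of compound 2, whose step was a 4.3-fold lower number from compound 1 to compound 2 (0.63 log units; beyond the scatter). For compound 4 a downward step of intermediate size is therefore expected, a 2.4-fold lower number from compound 1 to compound 4 (0.39 log units; beyond the scatter). Compound 4 is estimated at 9000 nM, range 4000 nM to 20000 nM.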

Compound 4, half-maximal effective concentration: 17000 nM
The estimate for compound 4 lay 1.9-fold (0.28 log units) below the measured number; the range from low to high includes it.
By their numbers in this assay, from the lowest: compound 2; then compounds 3, 4 and 1 (each within the scatter of the next).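

Swapping pyrimidin-5-yl for 3-methylphenyl leaves the number within the scatter (a 1.3-fold lower number from compound 1 to compound 4 (0.11 log units; within the scatter)), and 3-methylphenyl for 2-methoxyphenyl does the same (a 1.2-fold higher number from compound 3 to compound 4 (0.06 log units; within the scatter)). A carbocyclic ring at this position therefore does not by itself lower the number, as compound 4 and compound 3 show; the separation belongs to the 3-chloro-2-methylphenyl of compound 2 (a 3.3-fold higher number from compound 2 to compound 4 (0.52 log units; beyond the scatter)). No measurement at hand accounts for this gap.

Open is whether the chloro or the added methyl of compound 2 carries the step, as neither a 3-chlorophenyl nor a 2-methylphenyl is among the compounds shown. Also open, on these data alone, is how an amine on this ring would read.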